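The compounds below may be only part of what the source reports. "The series", "measured", "known", "first", "only" and "open" are said of these compounds alone.

Series notes. Compound 1 `O=C(c1ccccn1)N1N=CCC1c1ccccc1` gives 2.4 in a physicochemical assay for lipophilicity, read by HPLC, measured as chromatographic lipophilicity, at pH 7.4; a higher number here means a more lipophilic compound, a lower number a more polar compound. Compound 2 `O=C(c1cnco1)N1CCC(C(=O)N2N=CC[C@H]2c2ccccc2)CC1` gives 2.7 in this assay; the two numbers sit within the scatter of each other, so compound 1 is neither set apart from nor ordered against compound 2 on these data. Among the measured compounds shown here, no step between measured compounds that differ in one place is available so far. Compound 3 `O=C(c1ccccc1)N1N=CCC1c1ccccc1` is the next compound to be measured in this assay; against compound 1 it differs in one place: phenyl in place of pyridin-2-yl on a carbonyl carbon. For the measured compounds named here, no measured pair shows this change, so its size rests on the change itself rather than on a measured step. The step expected in this assay is a number 1.00 log units higher from compound 1 to compound 3 (beyond the scatter), upward and beyond the scatter. Compound 3 is estimated at 3.4, with a range from 2.9 to 3.9.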

Compound 3, distribution coefficient: 4.6
The estimate for compound 3 lay 1.20 log units below the measured number; measured number above the stated range.
By their numbers in this assay, from the lowest: compounds 1 and 2 (each within the scatter of the next); then compound 3.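

Among the compounds shown here, on the carbonyl carbon of the shared core, phenyl in place of pyridin-2-yl gives the first measured step in this assay: a number 2.20 log units higher from compound 1 to compound 3 (beyond the scatter), large and beyond the scatter. The read-out at this position therefore responds strongly to a swap that keeps the count of heavy atoms and removes only the ring nitrogen, with its one hydrogen-bond acceptor. Nothing at hand accounts for the size of this step.

This single pair cannot show whether the step in this assay would hold on a different core, as compound 2 differs from compound 1 in more than one place and offers no comparison. As far as these compounds go, how a pyrimidinyl or cyclohexyl group on this carbonyl carbon would read against phenyl and pyridin-2-yl also remains open.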